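Swapping one naphthyl for another on a sulfonyl group

The source may hold more compounds than are shown below. What is called first, only, known or untested is meant among the compounds shown, and "the series" means these compounds.

Compound 3 `O=S(=O)(Nc1ncc(C(Oc2ccc3cc(Br)ccc3c2)c2ccc(Cl)cc2)s1)c1ccc2ccccc2c1` is one of three measured analogues, all sharing a core and differing only in the aryl group on the sulfonyl sulfur. In an ADME assay on HepG2 2.2.15 cells (Homo sapiens) for cytotoxicity (on this read-out higher numbers stand for lower toxicity in this test and lower numbers for higher toxicity in this test), compound 3 gives > 50000 nM, a limit of the assay rather than a number. Compound 1 `CCc1ccc(S(=O)(=O)Nc2ncc(C(Oc3ccc4cc(Br)ccc4c3)c3ccc(Cl)cc3)s2)cc1` gives > 50000 nM in this assay, likewise a limit. Compound 2 `O=S(=O)(Nc1ncc(C(Oc2ccc3cc(Br)ccc3c2)c2ccc(Cl)cc2)s1)c1ccc(Cl)cc1` is recorded as "not toxic" (no number reported) in this assay, without a number. The step that the two limits leave unreadable from compound 1 to compound 3 therefore cannot be sized. Compound 4 `Cc1ccc(S(=O)(=O)Nc2ncc(C(Oc3ccc4cc(Br)ccc4c3)c3ccc(Cl)cc3)s2)c2ccccc12` carries 4-methylnaphthalen-1-yl in place of naphthalen-2-yl on a sulfonyl sulfur. Because (the limit of > 50000 nM in this assay, at which 2 of the 3 values shown sit), compound 4 is expected to sit at the same limit, with an expected step that the limit leaves unreadable from compound 3 to compound 4. The estimate for compound 4 is 60000 nM, within 30000 nM to 200000 nM.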

Compound 4, half-maximal cytotoxic concentration: > 50000 nM
Compound 4 ended at the assay's limit; the forecaster's own chance of this, stated with the estimate: 80%; the middle value is on the limit's open side.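

Compound 4, like compound 1 and compound 3, sits at a limit in this assay, so no step among these compounds can be read. The compounds shown leave open whether these sulfonyl aryl groups differ in cytotoxicity at all.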